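Inverting one stereocentre from compound 3 to compound 4

The source may hold more compounds than are shown below. What is called first, only, known or untested is meant among the compounds shown, and "the series" means these compounds.

In an ADME assay on NCM460 cells (Homo sapiens) for cytotoxicity, read by CCK-8 assay, with a stated time of 48 h (on this read-out higher numbers stand for weaker inhibition and lower numbers for stronger inhibition), compound 3 (`COc1ccc(/C=C\c2cc(OC)c(OC)c(OC)c2)cc1OCc1ccc(CN2CC[C@H](O)C2)cc1`) gives 51000 nM and stands level with compound 1 (`COc1ccc(/C=C\c2cc(OC)c(OC)c(OC)c2)cc1OCc1ccc(CNCCO)cc1`), which gives 39000 nM as its value. Compound 2 (`COc1ccc(/C=C\c2cc(OC)c(OC)c(OC)c2)cc1OCc1ccc(CN2CC(C(=O)O)C2)cc1`) gives > 50000 nM as a limit of the assay.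

Compound 4 (`COc1ccc(/C=C\c2cc(OC)c(OC)c(OC)c2)cc1OCc1ccc(CN2CC[C@@H](O)C2)cc1`) differs from compound 3 as follows: the two compounds have the same atoms and bonds and differ only in configuration as drawn: 1 of 2 stereo elements differ; a stereocentre at a saturated ring carbon is drawn S in compound 3 and R in compound 4. Among the measured compounds shown here, no measured pair tests configuration directly. The nearest evidence is the amine exchanges, a 1.3-fold higher number from compound 1 to compound 3 (0.12 log units; within the scatter) and an at least 1.2-fold higher number from compound 1 to compound 2 (0.10 log units; that floor lies within the scatter), and neither exceeds the scatter. No step beyond the scatter is therefore expected in this assay, and the expected step is a 1.1-fold lower number from compound 3 to compound 4 (0.03 log units; within the scatter) in size. Compound 4 is estimated at 48000 nM (range 27000 nM to 85000 nM).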

Compound 4, half-maximal inhibitory concentration: 53000 nM
Compound 4: the middle estimate sits 1.1-fold (0.04 log units) below what was measured; low and high end bracket the measured number.
By their numbers in this assay, from the lowest: compounds 1, 3 and 4 (each within the scatter of the next).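

In this assay, configuration at the saturated ring carbon is now tested directly, and a 1.0-fold higher number from compound 3 to compound 4 (0.02 log units; within the scatter) shows no separation, with nothing else differing: the fact that compounds 3 and 4 differ only in the configuration as drawn The R form also stays level with the open-chain amine, with a 1.4-fold higher number from compound 1 to compound 4 (0.13 log units; within the scatter). Compound 2 gives > 50000 nM, which is a limit, and the steps involving it cannot be read: the limit of > 50000 nM in this assay, at which 1 of the 4 values shown sits.

Still open, on these data alone, is whether a primary amine, a piperidine or a longer hydroxyalkyl chain on the same saturated chain carbon would give a step beyond the scatter.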